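This account rests on a few compounds, and the source may have more. Where it says the series, first, only, none or still open, it means among the compounds named here.

Measured in an ADME assay (liver) for metabolic stability, with Liver microsome (Homo sapiens) as the target, using microsomes and NADPH, with a stated time of 30 min, tested at 1 uM; on this read-out lower numbers stand for slow clearance and higher numbers for fast clearance:
- compound 1 `CS(=O)(=O)Nc1cccc(-c2cc(C(O)(C(F)(F)F)C(F)(F)F)cnc2N2CCN(S(=O)(=O)c3ccc(N)nc3)CC2)c1`: 40 mL.min-1.g-1
- compound 2 `NC(=O)c1cccc(-c2cc(C(O)(C(F)(F)F)C(F)(F)F)cnc2N2CCN(S(=O)(=O)c3ccc(N)nc3)CC2)c1`: 17 mL.min-1.g-1
- compound 3 `Nc1ccc(S(=O)(=O)N2CCN(c3ncc(C(O)(C(F)(F)F)C(F)(F)F)cc3-c3ccc4sccc4c3)CC2)cn1`: 48 mL.min-1.g-1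

Compound 3 stands with the faster-cleared compounds in this small set. The measured 1.2-fold higher number from compound 1 to compound 3 (0.08 log units; within the scatter) stays inside the scatter, whereas a 2.8-fold higher number from compound 2 to compound 3 (0.45 log units; beyond the scatter) goes beyond it.

The next molecule, compound 4 `Nc1ccc(S(=O)(=O)N2CCN(c3ncc(C(O)(C(F)(F)F)C(F)(F)F)cc3-c3cc4ccccc4s3)CC2)cn1`, has the same atoms joined differently: 1-benzothiophen-2-yl in place of 1-benzothiophen-5-yl on an aromatic carbon. The change lies on an aromatic carbon of a six-membered aromatic ring with 1 nitrogen, the carbon where compound 1, compound 2 and compound 3 also differ. Going by the values given here, no measured pair compares two attachment points of one group, so there is no direct guide. Replacing the whole group at this carbon gave only modest changes, such as a 2.4-fold lower number from compound 1 to compound 2 (0.37 log units; beyond the scatter), and the largest was a 2.8-fold higher number from compound 2 to compound 3 (0.45 log units; beyond the scatter). A smaller shift, within the scatter, therefore seems likely for a change that keeps every atom.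

The expected change is a 1.0-fold higher number from compound 3 to compound 4 (0.02 log units; within the scatter).

For compound 4 the estimated value is 50 mL.min-1.g-1, with an expected range from 25 mL.min-1.g-1 to 95 mL.min-1.g-1.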

Compound 4, intrinsic clearance in microsomes: < 14 mL.min-1.g-1
Compound 4: a limit, no number; the forecaster's own chance of this, stated with the estimate: 5%; middle value at least 3.5-fold (0.55 log units) away from the limit.
By their numbers in this assay, from the lowest: compound 2; then compounds 1 and 3 (each within the scatter of the next). At a limit, below all of these: compound 4.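

In this assay, going by these compounds alone, the same atoms joined differently give an at least 3.4-fold lower number from compound 3 to compound 4 (0.53 log units; beyond the scatter), so at this carbon the attachment point of the benzothiophene matters, whereas the earlier compounds showed only swaps of a whole group. Against those other groups, the result gives an at least 2.8-fold lower number from compound 1 to compound 4 (0.45 log units; beyond the scatter), and also an at least 1.2-fold lower number from compound 2 to compound 4 (0.08 log units; that floor lies within the scatter), a floor that does not by itself separate the two compounds. Compound 4 stands only as a limit of the assay, not as a number: the limit of < 14 mL.min-1.g-1 in this assay, at which 1 of the 4 values shown sits.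

From the compounds shown here alone, whether the low reading belongs to the 2-yl attachment of this particular bicyclic group stays open, and a 1-benzofuran-2-yl or a plain thiophen-2-yl group at this carbon would test that. A 1-benzothiophen-3-yl group would show whether the outcome follows the ring carbon used for attachment.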